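Trifluoromethylphenyl Urea in a Weakly Active Series

The source may report more compounds than this note shows. Statements on the series, on what has been measured and on what is new or still open speak of the compounds shown alone.

The study concerns compounds on a shared core tested in a functional assay on NCI-H226 cells (Homo sapiens) for inhibition, read by sulforhodamine B assay, with a stated time of 48 h; a lower number here means a stronger inhibitor of growth, a higher number a weaker inhibitor of growth. Compound 1, `O=C(Nc1cccc(-n2cc(-c3ccncc3)c(-c3ccc(Cl)c(O)c3)n2)c1)Nc1ccc(Cl)c(Cl)c1`, bears a urea whose outer ring is a 3,4-dichlorophenyl. In this assay compound 1 gives only a limit, > 32500 nM, and not a number. Compound 2, `COc1cc(-c2nn(-c3cccc(NC(=O)c4ccc(Cl)c(C(F)(F)F)c4)c3)cc2-c2ccncc2)ccc1Cl`, is an amide relative; in this assay compound 2 likewise reaches only the limit, > 32500 nM. Compound 3, `COc1cc(-c2nn(-c3cccc(NC(=O)c4cccc(C(F)(F)F)c4)c3)cc2-c2ccncc2)ccc1Cl`, lacks one chloro of compound 2; in this assay compound 3 gives 27000 nM. Going by the values given here, the single measured step, an at least 1.2-fold lower number from compound 2 to compound 3 (0.08 log units; that floor lies within the scatter), lies within the scatter, and two of the three values share the same limit (the limit of > 32500 nM in this assay, at which 2 of the 3 values shown sit). Compound 4, `O=C(Nc1cccc(-n2cc(-c3ccncc3)c(-c3ccc(Cl)c(O)c3)n2)c1)Nc1cccc(C(F)(F)F)c1`, differs from compound 1 by 3-(trifluoromethyl)phenyl in place of 3,4-dichlorophenyl on an amide-type nitrogen. Among the compounds with values here, no measured step tracks this change; the one step that exists concerns a different group elsewhere on the molecule. Since compound 1 sits at a limit, only a move to a lower number could be seen. Compound 4 is expected to stay near that limit, with an estimated value of 30000 nM and a range from 12000 nM to 80000 nM. That estimate means an expected step of an at least 1.0-fold lower number from compound 1 to compound 4 (0.03 log units; that floor lies within the scatter).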

Compound 4, concentration for total growth inhibition: > 32500 nM
Compound 4: only a limit was reported; the forecaster's own chance of this, stated with the estimate: 55%; middle value at least 1.0-fold (0.03 log units) away from the limit.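

In this assay compound 4 gives only a limit, > 32500 nM. Compound 1 also stands at a limit, so no step between compound 1 and compound 4 can be read: the limit of > 32500 nM in this assay, at which 3 of the 4 values shown sit.

The compounds shown leave open whether 3-(trifluoromethyl)phenyl and 3,4-dichlorophenyl on the amide-type nitrogen differ at all in growth inhibition.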